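Lengthening the methoxymethyl chain of compound 2

The source may report more compounds than this note shows. Statements on the series, on what has been measured and on what is new or still open speak of the compounds shown alone.

compound 1 `CSCC1OC(n2c(Cl)nc3cc(Cl)c(Cl)cc32)C(OC(C)=O)C1OC(C)=O` gives 70000 nM
compound 2 `COC[C@H]1OC(n2c(Cl)nc3cc(Cl)c(Cl)cc32)[C@H](O)[C@@H]1O` gives 90000 nM

Going by the values given here, in a functional assay on KB cells (Homo sapiens) for inhibition (a lower number here means a stronger inhibitor, a higher number a weaker inhibitor), compound 2 at 90000 nM sits within the scatter of compound 1 at 70000 nM and no step between measured compounds differing in one place is available. Compound 3 `CCCCOC[C@H]1OC(n2c(Cl)nc3cc(Cl)c(Cl)cc32)[C@H](O)[C@@H]1O` carries propyl in place of hydrogen on a saturated chain carbon bound to an oxygen on a saturated carbon as propyl in place of hydrogen on a saturated chain carbon bound to an oxygen on a saturated carbon, turning methoxymethyl into butoxymethyl. In this assay no step beyond the scatter is expected, in either direction. The expected change is a 1.2-fold lower number from compound 2 to compound 3 (0.08 log units; within the scatter) and would stay small. Compound 3 is estimated at 75000 nM with an expected range from 30000 nM to 160000 nM in this series.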

Compound 3, half-maximal inhibitory concentration: 60000 nM
For compound 3 the middle estimate is 1.3-fold (0.10 log units) above the measured one; low and high end bracket the measured number.
By their numbers in this assay, from the lowest: compounds 3, 1 and 2 (each within the scatter of the next).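

In this assay, going by these compounds alone, butoxymethyl in place of methoxymethyl gives a 1.5-fold lower number from compound 2 to compound 3 (0.18 log units; within the scatter) as the first one-place reading at this position. Propyl in place of hydrogen on this saturated chain carbon therefore leaves compound 3 inseparable from compound 2, so the chain length can grow this far without a step beyond the scatter. No measured evidence bears on this result. From the compounds shown here alone, whether a longer chain such as octyl, or a chain ending in an amine or a carboxylic acid, would give a step beyond the scatter remains open.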